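A few compounds are considered here, and "the series" means these few. Any claim that something is new, unique, unknown or untested is made for them only; others in the source may bear on it.

Measured compounds in an ADME assay on PC-3 cells (Homo sapiens) for cytotoxicity; a higher number here means a weaker inhibitor, a lower number a stronger inhibitor:
- compound 1 `O=C1Nc2c(Br)cc(Br)cc2C1=O` gives 101000 nM
- compound 2 `O=C1Nc2cc(Br)c(Br)cc2C1=O` gives 41000 nM
- compound 3 `O=C1Nc2c(I)cc(I)cc2C1=O` gives 71900 nM

Within this small set, compound 2 carries the lowest number of the three in this assay; compound 3 sits close to it, within the usual scatter, while compound 1 lies further off, beyond it. Compound 4 `O=C1Nc2c(cc(Br)c(Br)c2Br)C1=O` is not yet measured. The change from compound 2 is bromo in place of hydrogen on an aromatic carbon. Within the data shown here, no step between measured compounds is available to calibrate this change, so the expectation rests on the narrow spread of the three values only: no movement beyond the scatter is expected in either direction. For compound 4 the estimate is 45000 nM (range 15000 nM to 120000 nM), which corresponds to an expected step of a 1.1-fold higher number from compound 2 to compound 4 (0.04 log units; within the scatter).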

Compound 4, half-maximal inhibitory concentration: 25900 nM
Beside the measured number, compound 4's estimate is 1.7-fold (0.24 log units) above it, and the stated range covers the measured number.
By their numbers in this assay, from the lowest: compounds 4, 2, 3 and 1 (each within the scatter of the next, the first and the last beyond it).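

In this assay a third bromo on the aromatic carbon ortho to a bromo group and ortho to a fused ring gives a 1.6-fold lower number from compound 2 to compound 4 (0.20 log units; within the scatter) and so stays within the scatter at this position. The same change read from the other dibromo compound gives a 3.9-fold lower number from compound 1 to compound 4 (0.59 log units; beyond the scatter) as a modest step beyond the scatter, so the size of the step depends on the compound it starts from. Nothing measured here explains that difference.

From the compounds shown here alone, whether this position accepts anything other than a halogen remains open. An amine, a methoxy group or a carboxylic acid on this carbon would test that.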